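This account rests on a few compounds, and the source may have more. Where it says the series, first, only, none or still open, it means among the compounds named here.

Working notes on the lactone series.

Compound 1 `O=C1OC[C@H](Cc2ccccc2)[C@H]1Cc1ccccc1` gives 77000 nM in a functional assay on HL-60 cells (Homo sapiens) for cytotoxicity, read by WST assay, with a stated time of 48 h; on this read-out higher numbers stand for an effect only at larger amounts of compound and lower numbers for an effect already at smaller amounts. For the measured compounds named here, compound 2 `COc1ccccc1C[C@H]1C(=O)OC[C@@H]1Cc1ccccc1` carries the change methoxy in place of hydrogen on an aromatic carbon and gives 79000 nM in this assay; the step of a 1.0-fold higher number from compound 1 to compound 2 (0.01 log units; within the scatter) is the only single-place comparison measured so far, and it shows that this substitution left the read-out essentially unchanged.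

Compound 3 `O=C1OC[C@H](Cc2ccc(O)cc2)[C@H]1Cc1ccc(Cl)c(Cl)c1` gives 37000 nM in this assay, the lowest of the three numbers. The difference between the core of compound 3 and the core of compound 1 is not broken down here.

Compound 4 `COc1cc(C[C@H]2COC(=O)[C@@H]2Cc2ccc(Cl)c(Cl)c2)ccc1O` is not yet measured. It differs from compound 3 by methoxy in place of hydrogen on an aromatic carbon, the same kind of change as that from compound 1 to compound 2. The surroundings are not identical: in compound 2 the methoxy sits ortho to a large group, whereas in compound 4 it sits ortho to a hydroxy group and meta to a large group.

Given that the step of a 1.0-fold higher number from compound 1 to compound 2 (0.01 log units; within the scatter) was within the scatter, a similarly small step a 1.0-fold lower number from compound 3 to compound 4 (0.01 log units; within the scatter) is expected for compound 4 in this assay. Compound 4 is therefore estimated at 36000 nM, with a range of 15000 nM to 85000 nM.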

Compound 4, half-maximal effective concentration: 36000 nM
Compound 4: the middle estimate sits on the measured number at the digits printed; measured number inside the range.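

In this assay, methoxy in place of hydrogen on an aromatic carbon gives a 1.0-fold lower number from compound 3 to compound 4 (0.01 log units; within the scatter), so on this second core too the change leaves the read-out where it was. Set beside the earlier step, the change carries from one core to the other with no difference that can be told apart: the same change on two cores in this assay, a 1.0-fold higher number (0.01 log units; within the scatter) from compound 1 to compound 2 and a 1.0-fold lower number (0.01 log units; within the scatter) from compound 3 to compound 4, 1.1-fold (0.02 log units) apart, within the scatter of two such steps

This holds for these two pairs and this read-out only; the surroundings of the methoxy are not the same in the two pairs, so core and place on the ring are not separated, and nothing follows for other positions or other cores.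

Still open, from the compounds shown here alone, is whether any group at these places moves the number, for instance an amine, a carboxylic acid or a longer chain such as ethoxy in place of the methoxy. Also open, going by these compounds, are the separate shares of the hydroxy group and the chlorine atoms in the core of compound 3, which differs from the core of compound 1 in more than one place.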